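From Methoxyphenyl to Naphthyl on the Ring Nitrogen

This account rests on a few compounds, and the source may have more. Where it says the series, first, only, none or still open, it means among the compounds named here.

Of the compounds shown here, two sharing one core have been measured. Compound 1 `CC(C)[C@@H]1CC[C@@H](C)C[C@@]12N(C)C(=O)[C@@H]1[C@H]3C(=O)NC(=O)[C@H]3ON12` carries a hydrogen on an amide-type nitrogen in a ring; in a functional assay, read by spectrophotometry, with a stated time of 2 h, tested at 2 mg/mL (on this read-out higher numbers stand for a stronger effect at the one concentration tested and lower numbers for a weaker effect), compound 1 gives 37.1%. Compound 2 `COc1ccc(N2C(=O)[C@H]3[C@H](ON4[C@@H]3C(=O)N(C)[C@@]43C[C@H](C)CC[C@H]3C(C)C)C2=O)cc1` carries a 4-methoxyphenyl on that nitrogen, and in this assay compound 2 gives 55.7%. The measured step is a number 18.6 percentage points higher from compound 1 to compound 2 (beyond the scatter). Compound 2 therefore stands highest of the two numbers, with compound 1 the nearest and lower beyond the scatter.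

Compound 3 `CC(C)[C@@H]1CC[C@@H](C)C[C@@]12N(C)C(=O)[C@@H]1[C@H]3C(=O)N(c4ccc5ccccc5c4)C(=O)[C@H]3ON12` differs from compound 2 in one place: naphthalen-2-yl in place of 4-methoxyphenyl on an amide-type nitrogen in a ring. Going by the values given here, only one measured step bears on this, a number 18.6 percentage points higher from compound 1 to compound 2 (beyond the scatter), which put 4-methoxyphenyl in place of hydrogen. Among the compounds with values here, no measured step exchanges one such group for another, so the direction is uncertain, and a step in either direction or none beyond the scatter is plausible. As an estimate, compound 3 is expected to give 55% in this assay, within 35% to 75%, an expected step of a number 0.7 percentage points lower from compound 2 to compound 3 (within the scatter).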

Compound 3, a percentage reported as activity, at one concentration (the size of the read-out at that concentration, not a potency): 36.5%
For compound 3 the middle estimate is 18.5 percentage points above the measured one; measured number inside the range.
By their numbers in this assay, from the lowest: compounds 3 and 1 (each within the scatter of the next); then compound 2.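

In this assay, an aromatic group on this nitrogen does not by itself raise the number: naphthalen-2-yl in place of 4-methoxyphenyl gives a number 19.2 percentage points lower from compound 2 to compound 3 (beyond the scatter), and naphthalen-2-yl in place of hydrogen gives a number 0.6 percentage points lower from compound 1 to compound 3 (within the scatter). The earlier step alone could have been read as a gain from any aromatic ring at this position, but the gain now belongs to 4-methoxyphenyl and does not extend to naphthalen-2-yl. No measurement here explains why these two groups differ.

Going by these compounds alone, what remains open is whether the gain needs the methoxy group or only a single aromatic ring, which a plain phenyl group on this nitrogen would help to separate. On these data alone, it is also open how a non-aromatic group, such as an ethyl chain, would fare at this position.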